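The source may report more compounds than this note shows. Statements on the series, on what has been measured and on what is new or still open speak of the compounds shown alone.

Working notes on the series. In a functional assay on WM 266-4 cells (Homo sapiens) for antiproliferative activity, read by MTT assay, with a stated time of 48 h (on this read-out higher numbers stand for weaker inhibition and lower numbers for stronger inhibition), compound 2 `Fc1ccc(C2=NN(c3nc(-c4ccc(Br)cc4)cs3)C(c3cccs3)C2)cc1` gives 220 nM, the lowest number among the three measured compounds. Compound 1 `COc1ccc(C2=NN(c3nc(-c4ccc(Br)cc4)cs3)C(c3cccs3)C2)cc1` gives 5870 nM in this assay, and compound 3 `Fc1ccc(C2=NN(c3nc(-c4ccc(C(F)(F)F)cc4)cs3)C(c3cccs3)C2)cc1` gives 5120 nM. Going by the values given here, both steps leading out of compound 2 are large and beyond the scatter; the one towards compound 3 reads a 23-fold higher number from compound 2 to compound 3 (1.37 log units; beyond the scatter) and concerns the other aryl ring, so it does not bear on the change considered here.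

Compound 4 `Cc1ccc(C2=NN(c3nc(-c4ccc(Br)cc4)cs3)C(c3cccs3)C2)cc1` is not yet measured. Relative to compound 2 the change is methyl in place of fluoro on an aromatic carbon: fluoro leaves and methyl enters, each a single heavy atom, on an aromatic carbon of a six-membered aromatic ring of carbon only, para to a large group; read one bond further out, 4-fluorophenyl becomes 4-methylphenyl. The step that bears on it is the one at the same aromatic carbon, methoxy to fluoro: a 27-fold lower number from compound 1 to compound 2 (1.43 log units; beyond the scatter). Methoxy there gave a much higher number than fluoro; methyl is neither group, so a moderate rise in the number is expected, smaller than the methoxy case. The estimate for compound 4 in this assay is 800 nM, range 200 nM to 3500 nM, meaning an expected step of a 3.6-fold higher number from compound 2 to compound 4 (0.56 log units; beyond the scatter).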

Compound 4, half-maximal inhibitory concentration: 18400 nM
The estimate for compound 4 lay 23-fold (1.36 log units) below the measured number; the whole stated range lies below it.
By their numbers in this assay, from the lowest: compound 2; then compounds 3 and 1 (each within the scatter of the next); then compound 4.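

In this assay, going by these compounds alone, the replacement of fluoro by methyl on this aromatic carbon gives an 84-fold higher number from compound 2 to compound 4 (1.92 log units; beyond the scatter) and is the largest step so far, which shows that a high number here does not require an oxygen-linked group such as methoxy. Methoxy is also not the worst of the groups at this carbon: methyl reads a 3.1-fold higher number from compound 1 to compound 4 (0.50 log units; beyond the scatter) and so stands beyond methoxy, leaving fluoro as the only one of the three groups with a low number while bromo sits on the other aryl ring. No measurement in hand accounts for the gap between fluoro and the other two groups.

The compounds shown leave open how chloro, a hydroxyl group or an amine would read at this carbon, and whether a longer chain such as ethyl would raise the number further than methyl does. Also open is whether the same order of fluoro, methoxy and methyl holds with trifluoromethyl in place of bromo, as compound 3 is the only compound shown with that partner.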